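Carbamoyl to carbonyloxy: estimating growth inhibition for compound 3

The source may report more compounds than this note shows. Statements on the series, on what has been measured and on what is new or still open speak of the compounds shown alone.

Compound 1 `CCCCCCCCCCCC[C@@H](O)[C@H]1CC[C@H]([C@H](O)CCCCCCCCCCNCc2ccnn2C)O1`: 129 nM
Compound 2 `CCCCCCCCCCCC[C@@H](O)[C@H]1CC[C@H]([C@H](O)CCCCCCCCCCC(=O)Nc2ccnn2C)O1`: 3310 nM

In a functional assay on DMS-114 cells (Homo sapiens) for inhibition, read by sulforhodamine B assay, with a stated time of 48 h (on this read-out higher numbers stand for weaker inhibition of growth and lower numbers for stronger inhibition of growth), compound 2, at 3310 nM, holds the higher of the two measured numbers. Compound 3 `CCCCCCCCCCCC[C@@H](O)[C@H]1CC[C@H]([C@H](O)CCCCCCCCCCOC(=O)c2ccnn2C)O1` differs from compound 2 in one place: ((1-methyl-1H-pyrazol-5-yl)carbonyl)oxy in place of (1-methyl-1H-pyrazol-5-yl)carbamoyl on a saturated chain carbon, ten or more bonds along the chain from an oxygen on a saturated carbon and a saturated ring carbon. Going by the values given here, the only measured step at this place on the chain, a 26-fold higher number from compound 1 to compound 2 (1.41 log units; beyond the scatter), was large, but it involved a different swap, so it gives no direction for this one. Only a small change is therefore expected, within the scatter: a 1.7-fold lower number from compound 2 to compound 3 (0.22 log units; within the scatter). Compound 3 is estimated at 2000 nM, with an expected range of 500 nM to 8000 nM.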

Compound 3, concentration for 50% growth inhibition: 407 nM
Beside the measured number, compound 3's estimate is 4.9-fold (0.69 log units) above it; the whole stated range lies above it.
By their numbers in this assay, from the lowest: compound 1; then compound 3; then compound 2.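

In this assay, the way the 1-methyl-1H-pyrazol-5-yl ring is attached to the chain clearly matters: swapping the carbamoyl link for carbonyloxy gives an 8.1-fold lower number from compound 2 to compound 3 (0.91 log units; beyond the scatter). That swap does not match the amine link, with a 3.2-fold higher number from compound 1 to compound 3 (0.50 log units; beyond the scatter), so compound 1 keeps the lowest number of the three. Nothing here explains why the link has this effect.

As far as these compounds go, whether a carboxylic acid at the chain end or a longer chain carrying the carbonyloxy group would lower the number further stays open. All three compounds share the 1-methyl-1H-pyrazol-5-yl ring, so its own contribution is also unknown.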